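Shortening the urea substituent from ethyl to methyl

The compounds below may be only part of what the source reports. "The series", "measured", "known", "first", "only" and "open" are said of these compounds alone.

Measured compounds:
- compound 1, `N#CC1CN1C(N)=O`: > 90000 nM (a limit of the assay, not a number)
- compound 2, `CCNC(=O)N1CC1C#N`: 14000 nM

In a functional assay on OVCAR-3 cells (Homo sapiens) for inhibition (a higher number here means a weaker inhibitor, a lower number a stronger inhibitor), compound 1 reaches only the limit of the assay, reported as > 90000 nM. Going by the values given here, in the same assay compound 2 gives 14000 nM, which is the only actual number among the two values shown. Among the compounds with values here, the single measured step, an at least 6.4-fold lower number from compound 1 to compound 2 (0.80 log units; beyond the scatter), is itself anchored to that limit, as the limit of > 90000 nM in this assay, at which 1 of the 2 values shown sits, records, so its true size is known only as a lower bound.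

Compound 3, `CNC(=O)N1CC1C#N`, differs from compound 2 by hydrogen in place of methyl on a saturated chain carbon bound to an amide-type nitrogen. Within the data shown here, this change runs part of the way back toward compound 1, which lacks any carbon on that nitrogen, so the measured step is the only guide and it points to a weakening. The expected step, a 2.1-fold higher number from compound 2 to compound 3 (0.33 log units; beyond the scatter), is therefore a modest rise in the number, smaller than the full step back to compound 1. Compound 3 is estimated at 30000 nM, within a range from 10000 nM to 90000 nM.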

Compound 3, half-maximal inhibitory concentration: 14000 nM
Compound 3: middle estimate off by 2.1-fold (0.33 log units), on the high side; the measured number falls inside the stated range.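

In this assay, going by these compounds alone, trading ethyl for methyl on this urea nitrogen gives no change at the digits printed from compound 2 to compound 3 (within the scatter), so the two chains cannot be told apart here, something the earlier compounds could not show. The benefit of a carbon substituent on that nitrogen therefore does not depend on the ethyl group, as methyl alone gives an at least 6.4-fold lower number from compound 1 to compound 3 (0.80 log units; beyond the scatter). Compound 1 stands at a limit of the assay rather than at a true number, so this step fixes only a lower bound on the size of the difference: the limit of > 90000 nM in this assay, at which 1 of the 3 values shown sits.

The compounds shown leave open whether a longer chain such as propyl or butyl, or a chain ending in an amine or a carboxylic acid, on this same nitrogen would lower the number, raise it or leave it in place. All three compounds also carry the same nitrile on the shared core, so what a carboxylic acid or a primary amide in its place would do remains an open question.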